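The source may hold more compounds than are shown below. What is called first, only, known or untested is meant among the compounds shown, and "the series" means these compounds.

Compound 1 `C=C1[C@@H](OC(C)=O)C[C@@H]2[C@](C)(CO[Si](C)(C)C(C)(C)C)[C@H](OC(C)=O)CC[C@@]2(C)[C@@H]1C[C@@H](Nc1ccc(OC)cc1)C1=CCOC1=O` carries, on an oxygen at one end of its shared core, a silicon-containing group, and at the other end an amine nitrogen bearing a 4-methoxyphenyl group. In a functional assay on KB cells (Homo sapiens) for cytotoxicity, read by sulforhodamine B assay (a higher number here means a weaker inhibitor, a lower number a stronger inhibitor), compound 1 gives 5630 nM. Two companions differ from it only at that amine nitrogen. Compound 2 `C=C1[C@@H](OC(C)=O)C[C@@H]2[C@](C)(CO[Si](C)(C)C(C)(C)C)[C@H](OC(C)=O)CC[C@@]2(C)[C@@H]1C[C@@H](Nc1cccc(F)c1)C1=CCOC1=O` bears a 3-fluorophenyl there and in this assay gives 4560 nM; compound 3 `C=C1[C@@H](OC(C)=O)C[C@@H]2[C@](C)(CO[Si](C)(C)C(C)(C)C)[C@H](OC(C)=O)CC[C@@]2(C)[C@@H]1C[C@@H](Nc1ccc(C(=O)O)cc1)C1=CCOC1=O` bears a 4-carboxyphenyl and gives 5540 nM. Set against them, compound 1 shows a 1.2-fold lower number from compound 1 to compound 2 (0.09 log units; within the scatter) and a 1.0-fold lower number from compound 1 to compound 3 (0.01 log units; within the scatter), and between the two companions the change is a 1.2-fold higher number from compound 2 to compound 3 (0.08 log units; within the scatter); the three numbers therefore sit together, with no separation beyond the scatter.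

Compound 4 `C=C1[C@@H](OC(C)=O)C[C@@H]2[C@](C)(COC=O)[C@H](OC(C)=O)CC[C@@]2(C)[C@@H]1C[C@@H](Nc1ccc(OC)cc1)C1=CCOC1=O` keeps the 4-methoxyphenyl of compound 1 and alters a different place: a group of 2 heavy atoms (1 carbon, 1 oxygen; no ring) in place of a group of 7 heavy atoms (6 carbon, 1 silicon; no ring), on an oxygen on a saturated carbon. None of the three measured steps touches this part of the molecule; each alters only the group on the amine nitrogen, and each stayed within the scatter. No measured step bears on the change from compound 1 to compound 4, and nothing in the shown numbers points in a direction. The expectation is therefore a step in this assay that stays within the scatter, a 1.1-fold lower number from compound 1 to compound 4 (0.05 log units; within the scatter), with a wide range reflecting the absence of any guiding step. Compound 4 is expected to give about 5000 nM, between 1500 nM and 15000 nM.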

Compound 4, half-maximal inhibitory concentration: 32700 nM
Compound 4: the middle estimate sits 6.5-fold (0.82 log units) below what was measured, outside the stated range (above it).
By their numbers in this assay, from the lowest: compounds 2, 3 and 1 (each within the scatter of the next); then compound 4.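

Until now, every change sat on the amine nitrogen and the numbers in this assay stayed together, so the shown compounds gave no sign that any single change could move this read-out. Among these compounds, the change at the oxygen on a saturated carbon gives the first step beyond the scatter, a 5.8-fold higher number from compound 1 to compound 4 (0.76 log units; beyond the scatter), so in this pair the formyl group goes with a weaker result than the group of 7 heavy atoms, containing silicon, that it replaces. No measurement shown here accounts for this step.

Going by these compounds, with only these two groups compared at this oxygen, it remains open whether the number follows the silicon atom, the count of heavy atoms or the carbonyl of the formyl group; a plain hydroxyl, an acetyl group or a longer chain such as a butanoyl group on this oxygen would help to separate these readings. On these data alone, it also remains open whether the formyl group gives a step of similar size when the amine nitrogen carries the 3-fluorophenyl of compound 2 or the 4-carboxyphenyl of compound 3.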